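Hydroxymethyl in place of carbamoyl on the shared core

This account rests on a few compounds, and the source may have more. Where it says the series, first, only, none or still open, it means among the compounds named here.

Three compounds of the series carry a value in a functional assay on the whole organism for inhibition, with Rattus norvegicus as the target, at a dose of 3 mg/kg; a higher number here means more inhibition at the dose given (going by the name of the read-out), a lower number less inhibition. Compound 3 `CCCCn1nc(C)c(C(N)=O)c1Cc1ccc(-c2ccccc2-c2nn[nH]n2)cc1` gives 74.9% and stands highest of the three; compound 1 `CCCCn1nc(C)c(C(=O)OC)c1Cc1ccc(-c2ccccc2-c2nn[nH]n2)cc1` gives 52.5% in this assay, and compound 2 `CCCCn1nc(Cc2ccc(-c3ccccc3-c3nn[nH]n3)cc2)c(C(=O)O)c1CC` gives 22.9%. Compound 2 differs from the others in more than one place, so its value is set beside them without a step. Among the measured compounds shown here, the one single-point step measured is a number 22.4 percentage points higher from compound 1 to compound 3 (beyond the scatter).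

Compound 4 `CCCCn1nc(C)c(CO)c1Cc1ccc(-c2ccccc2-c2nn[nH]n2)cc1` is the next step from compound 3: hydroxymethyl in place of carbamoyl on an aromatic carbon. This is a change at the same ring carbon that the measured step touches, with the carbamoyl now removed entirely rather than varied. For the measured compounds named here, the measured step shows that this position answers to change by a modest amount, and this is the only measured step that bears on the new one. A move away from the highest value of the set is therefore expected, of about a number 19.9 percentage points lower from compound 3 to compound 4 (beyond the scatter), with wide uncertainty. Compound 4 is estimated at 55% in this assay, in a range from 30% to 78%.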

Compound 4, a percentage reported as inhibition, in the whole organism at one dose (the size of the read-out at that dose, not a potency): 11.5%
For compound 4 the middle estimate is 43.5 percentage points above the measured one; measured number below the stated range.
By their numbers in this assay, from the lowest: compound 4; then compound 2; then compound 1; then compound 3.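

On the ring carbon of the shared core, this assay responds far more strongly when the carbonyl-bearing group gives way to hydroxymethyl than when one carbonyl-bearing group replaces another: the steps are a number 63.4 percentage points lower from compound 3 to compound 4 (beyond the scatter) and a number 41 percentage points lower from compound 1 to compound 4 (beyond the scatter), both large, against the modest a number 22.4 percentage points higher from compound 1 to compound 3 (beyond the scatter). Among the three groups compared at this carbon, carbamoyl and methoxycarbonyl both stand above hydroxymethyl, and hydroxymethyl falls well short of carbamoyl even with the same hydrogen-bond donor and acceptor counts. No measurement at hand accounts for the size of these steps.

Still open, on these data alone, is how a carboxylic acid at this carbon would compare on the unchanged core, since compound 2 carries that group but differs in more than one place. A nitrile or an aminomethyl group there would also test whether the carbonyl itself is what sets these values apart.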